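Swapping an ethyl for a methoxy on the second aryl ring

The source may hold more compounds than are shown below. What is called first, only, known or untested is meant among the compounds shown, and "the series" means these compounds.

Measured compounds:
- compound 1 `CC(C)(C)N(NC(=O)c1ccccc1Cl)C(=O)c1ccccc1Cl` gives 331 nM in an assay on cells for agonist activity at ecdysone receptor (Bombyx mori), read by a luciferase reporter, with a stated time of 24 h; on this read-out higher numbers stand for an effect only at larger amounts of compound and lower numbers for an effect already at smaller amounts
- compound 2 `CC(C)(C)N(NC(=O)c1ccccc1I)C(=O)c1ccccc1Cl` gives 1290 nM in this assay
- compound 3 `CCc1ccc(C(=O)NN(C(=O)c2ccccc2Cl)C(C)(C)C)cc1` gives 5.75 nM in this assay

Compound 3 stands lowest of the three, well beyond the scatter from both others. The two steps that lead to it, a 58-fold lower number from compound 1 to compound 3 (1.76 log units; beyond the scatter) and a 220-fold lower number from compound 2 to compound 3 (2.35 log units; beyond the scatter), show that exchanging the aryl group on one carbonyl carbon for 4-ethylphenyl changes the number a great deal, whereas a 3.9-fold higher number from compound 1 to compound 2 (0.59 log units; beyond the scatter) on the other ring is only modest.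

Compound 4 `COc1ccc(C(=O)NN(C(=O)c2ccccc2Cl)C(C)(C)C)cc1` differs from compound 3 in a single place: methoxy in place of ethyl on an aromatic carbon. Going by the values given here, no measured step alters the group at this place, so its size can only be guessed; the large steps into compound 3 do indicate that this part of the molecule matters. A modest rise in this assay is expected, a 5.2-fold higher number from compound 3 to compound 4 (0.72 log units; beyond the scatter), with the 4-ethylphenyl of compound 3 kept as the reference point. Compound 4 is therefore estimated at 30 nM, within a range of 8 nM to 120 nM.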

Compound 4, half-maximal effective concentration: 51.3 nM
The estimate for compound 4 lay 1.7-fold (0.23 log units) below the measured number; the measured number falls inside the stated range.
By their numbers in this assay, from the lowest: compound 3; then compound 4; then compound 1; then compound 2.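

In this assay, going by these compounds alone, replacing ethyl with methoxy gives an 8.9-fold higher number from compound 3 to compound 4 (0.95 log units; beyond the scatter), the first measured change at this place on the ring, so the number responds here even though both groups have 2 heavy atoms. The 4-methoxyphenyl group still compares well with the aryl groups of the earlier compounds, with a 6.5-fold lower number from compound 1 to compound 4 (0.81 log units; beyond the scatter) and a 25-fold lower number from compound 2 to compound 4 (1.40 log units; beyond the scatter), so among these compounds the advantage of a 4-substituted phenyl does not depend on ethyl alone. Nothing available explains why the methoxy compound gives a higher number than the ethyl compound.

Within the data shown here, with only two groups compared at this place, it remains open how a longer chain such as propyl, a hydroxyl, an amine or a single chlorine atom would behave there. On these data alone, it is also open whether the swap from ethyl to methoxy would have a similar effect if the 2-chlorophenyl on the other carbonyl were replaced.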